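Phenoxy to neopentyloxy: a step beyond the measured set

A few compounds are considered here, and "the series" means these few. Any claim that something is new, unique, unknown or untested is made for them only; others in the source may bear on it.

Measured compounds:
- compound 1, `CCS(=O)(=O)Nc1ccc(Oc2ccccc2)c(-c2cn(C)c(=O)c3[nH]ccc23)c1`: 14 nM
- compound 2, `Cn1cc(-c2cc(C(N)=O)ccc2Oc2ccccc2)c2cc[nH]c2c1=O`: 120 nM
- compound 3, `Cn1cc(-c2cc(S(N)(=O)=O)ccc2Oc2ccccc2)c2cc[nH]c2c1=O`: 56 nM

In a functional assay on MX1 cells (Homo sapiens) for antiproliferative activity, with a stated time of 72 h (a higher number here means that more compound is needed for the effect, a lower number that less compound is needed), compound 1 gives 14 nM, the lowest of the three numbers. Its neighbours differ from it only at the group on the aromatic carbon: a 4.0-fold higher number from compound 1 to compound 3 (0.60 log units; beyond the scatter), and an 8.6-fold higher number from compound 1 to compound 2 (0.93 log units; beyond the scatter). Between the two weaker compounds there is a 2.1-fold lower number from compound 2 to compound 3 (0.33 log units; beyond the scatter).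

Compound 4, `CCS(=O)(=O)Nc1ccc(OCC(C)(C)C)c(-c2cn(C)c(=O)c3[nH]ccc23)c1`, keeps the (ethylsulfonyl)amino group of compound 1 and changes the other side of the molecule: neopentyl in place of phenyl on an oxygen on an aromatic ring. Within the data shown here, none of the measured steps touches this position; all three vary the group on the aromatic carbon while the phenoxy group stays the same in compound 1, compound 2 and compound 3. Among the measured compounds shown here, there is therefore no measured step that bears on the change to compound 4, and the expectation rests on compound 1 alone as the starting point.

With no guide from the measured set, the estimate is wide. Compound 4 is expected to give 80 nM in this assay, within a range of 15 nM to 600 nM. The expected step is a 5.7-fold higher number from compound 1 to compound 4 (0.76 log units; beyond the scatter), a higher number than for compound 1, with low confidence.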

Compound 4, half-maximal effective concentration: 77 nM
Estimate against measurement, compound 4: 1.0-fold (0.02 log units) above; the measured number falls inside the stated range.
By their numbers in this assay, from the lowest: compound 1; then compounds 3, 4 and 2 (each within the scatter of the next, the first and the last beyond it).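

Among these compounds, until now every compound carried the phenoxy group, so the earlier steps spoke only to the group on the aromatic carbon. Among the compounds shown here, compound 4 gives the first reading at this position: in this assay, neopentyl in place of phenyl on an oxygen on an aromatic ring gives a 5.5-fold higher number from compound 1 to compound 4 (0.74 log units; beyond the scatter) with the (ethylsulfonyl)amino group held fixed. The step is modest and shows, for this pair, that the phenyl ring on that oxygen is not needed for antiproliferative activity, although compound 1, with the ring, keeps the lower number, and nothing shown here accounts for the size of the step.

The compounds shown leave open whether the ring itself or some other feature of the phenyl group matters, since a cyclohexyl group, a straight butyl chain or a pyridyl ring on the same oxygen would be needed to separate those readings. They also leave open whether neopentyl in place of phenyl gives a similar step when the (ethylsulfonyl)amino group is replaced by the carbamoyl group of compound 2 or the sulfamoyl group of compound 3.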